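Swapping a Ring Amine for a Short Chain on the Core

The compounds below may be only part of what the source reports. "The series", "measured", "known", "first", "only" and "open" are said of these compounds alone.

Measured compounds:
compound 1: `Cc1ccc2nc(N3CCNC(C)C3)nc(NCc3ccc(C(=O)NCc4ccc(F)cc4)cc3)c2c1`, 1400 nM
compound 2: `CN(C)CCCNc1nc(NCc2ccc(NC(=O)c3ccc(F)cc3)cc2)c2ccccc2n1`, 14000 nM
compound 3: `CNc1nc(NCc2ccc(C(=O)Nc3ccc(F)cc3)cc2)c2ccccc2n1`, 4100 nM

Of the compounds shown here, three have been tested so far, all built on the same shared core with an amine group at one position and a benzylamino arm carrying an amide at another. In a functional assay on SW480 cells (Homo sapiens) for inhibition, read by luminescence and resazurin assay, with a stated time of 3 days (a higher number here means a weaker inhibitor, a lower number a stronger inhibitor), compound 1 gives 1400 nM, the lowest of the three numbers. Compound 3 gives 4100 nM, a gap beyond the usual scatter, and compound 2 gives 14000 nM, further away still. Compounds 2 and 3 differ from compound 1 in more than one place, so none of these gaps can be tied to a single change.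

Compound 4, `CCCNc1nc(NCc2ccc(C(=O)NCc3ccc(F)cc3)cc2)c2cc(C)ccc2n1`, is the next to be measured. It differs from compound 1 in one place: propylamino in place of 3-methylpiperazin-1-yl on an aromatic carbon.

For the measured compounds named here, no measured pair shows this change on its own. Compounds 2 and 3 carry open-chain amines at that position, and both give higher numbers than compound 1, but each also differs in the amide and the core, so they give only a loose hint. A modest rise in the number, at or just beyond the scatter, is the expectation in this assay for the step of a 1.8-fold higher number from compound 1 to compound 4 (0.25 log units; within the scatter). Compound 4 is therefore estimated at 2500 nM, with a likely range of 900 nM to 7000 nM.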

Compound 4, half-maximal inhibitory concentration: 2200 nM
Beside the measured number, compound 4's estimate is 1.1-fold (0.06 log units) above it; the range from low to high includes it.
By their numbers in this assay, from the lowest: compounds 1, 4 and 3 (each within the scatter of the next, the first and the last beyond it); then compound 2.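

In this assay, replacing 3-methylpiperazin-1-yl with propylamino on an aromatic carbon of the shared core gives a 1.6-fold higher number from compound 1 to compound 4 (0.20 log units; within the scatter) and so does not separate the two compounds. For the compounds shown here, this is the first comparison in which only this group differs. The earlier compounds shown here could not provide one, as each differed from compound 1 in more than one place. For this pair, the six-membered non-aromatic ring and its second nitrogen can give way to an open chain with fewer heavy atoms without a step beyond the scatter, and nothing shown here offers an explanation for that result.

This single pair cannot show how much freedom the position allows more widely, such as whether a morpholine ring, a longer chain such as hexylamino, or a chain ending in a hydroxyl group would also stay within the scatter of compound 1. It also leaves open whether propylamino would behave in the same way with other amide arms or on a core without the methyl group of compound 1.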